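This account rests on a few compounds, and the source may have more. Where it says the series, first, only, none or still open, it means among the compounds named here.

Compounds measured so far:
Compound 1, `Cc1nc(COc2ccc(/C=C3\SC(=O)NC3=O)cc2)cs1`, gives 22.9%.
Compound 2, `O=C1NC(=O)/C(=C/c2ccc(OCCSc3nnc(-c4ccccc4)[nH]3)cc2)S1`, gives 22.9%.

Both values come from a functional assay on the whole organism (plasma, strain Wistar) with Rattus norvegicus as the target, with a stated time of 15 days, at a dose of 100 mg/kg by the oral route; a higher number here means a stronger effect of the compound at the dose given, a lower number a weaker effect. Compound 2 stands level with compound 1 at the digits reported: the two values lie within the usual scatter of repeated measurements, so nothing separates them, and no order can be read between them. For the measured compounds named here, no step between measured compounds that differ in a single place has been recorded, so the numbers so far give no direction for any structural change.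

Compound 3, `O=C1NC(=O)/C(=C/c2ccc(OCCSc3nnc(-c4ccccc4[N+](=O)[O-])[nH]3)cc2)S1`, is the next compound to be measured in this assay. It differs from compound 2 by nitro in place of hydrogen on an aromatic carbon; cut one bond further out, the same difference reads phenyl to 2-nitrophenyl. Going by the values given here, with no single-change step among the measured compounds to draw on, the change from compound 2 to compound 3 is expected to be a number 0.1 percentage points higher from compound 2 to compound 3 (within the scatter), a step of no size beyond the scatter in either direction. The activity of compound 3 in this assay is estimated at 23%, within a range from 8% to 40%.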

Compound 3, a percentage reported as activity, at one dose (the size of the read-out at that dose, not a potency): 26.8%
Compound 3: the middle estimate sits 3.8 percentage points below what was measured, within the range that was stated.
By their numbers in this assay, from the lowest: compounds 1, 2 and 3 (each within the scatter of the next).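

For the compounds shown here, the step from phenyl to 2-nitrophenyl is the first single-change comparison, and in this assay it reads as a number 3.9 percentage points higher from compound 2 to compound 3 (within the scatter). At this place, on an aromatic carbon ortho to a large group, the 3 heavy atoms of nitro can therefore take the place of hydrogen while the read-out stays within the scatter of compound 2. Nothing measured here speaks to what lies behind a step of this size.

On these data alone, it remains open whether an amine or a carboxylic acid at the same carbon would carry the read-out beyond the scatter, in either direction. Each value also stands at a single dose, so how these compounds would compare in potency is left open as well.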